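The source may report more compounds than this note shows. Statements on the series, on what has been measured and on what is new or still open speak of the compounds shown alone.

Compound 1, `CNC(=O)c1c(-c2ccccc2)c([C@H](C)Nc2ncnc(N)c2C#N)nc2ccc(F)cc12`, gives 1240 nM in an assay on Sf9 cells for inhibition of phosphatidylinositol 4,5-bisphosphate 3-kinase catalytic subunit beta isoform (Homo sapiens), with a stated time of 20 min; a higher number here means a weaker inhibitor, a lower number a stronger inhibitor.
Compound 2, `C[C@H](Nc1ncnc(N)c1C#N)c1nc2ccc(F)cc2c(C(=O)N(C)C)c1-c1ccccc1`, gives 545 nM in this assay.

Of these two, compound 2 has the lower number, and its step from compound 1 lies beyond the scatter: a 2.3-fold lower number from compound 1 to compound 2 (0.36 log units; beyond the scatter). Compound 3, `CC(C)NC(=O)c1c(-c2ccccc2)c([C@H](C)Nc2ncnc(N)c2C#N)nc2ccc(F)cc12`, has not yet been measured. It differs from compound 2 in one place: isopropylamino in place of dimethylamino on a carbonyl carbon. Among the measured compounds shown here, the only measured step that bears on this change is the one from compound 1 to compound 2, where a methyl in place of hydrogen on an amide-type nitrogen gave the lower number. Compound 3 brings a hydrogen back onto that nitrogen, while the isopropyl group it carries is larger than a methyl, so compound 3 is expected to move part of the way back toward compound 1, with a 1.7-fold higher number from compound 2 to compound 3 (0.22 log units; within the scatter). Compound 3 is therefore estimated at 900 nM in this assay, within a range of 400 nM to 2000 nM.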

Compound 3, half-maximal inhibitory concentration: 8050 nM
Compound 3: middle estimate off by 8.9-fold (0.95 log units), on the low side, outside the stated range (above it).
By their numbers in this assay, from the lowest: compound 2; then compound 1; then compound 3.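

Isopropylamino in place of dimethylamino on the carbonyl carbon gives a 15-fold higher number from compound 2 to compound 3 (1.17 log units; beyond the scatter) in this assay, so this position responds strongly to a change of only a few atoms. Compound 1 also carries the amide hydrogen, yet isopropyl in place of methyl on that nitrogen still gives a 6.5-fold higher number from compound 1 to compound 3 (0.81 log units; beyond the scatter), so the return of that hydrogen alone does not set the number for compound 3. Nothing available here explains why either change shifts the number as it does.

On these data alone, it remains open whether the loss follows the branching of isopropyl or simply the added carbon, a question that an ethyl group or a straight propyl chain on the same nitrogen would help settle. A pyrrolidine amide, which has no amide hydrogen, would show whether other fully substituted amides keep the lower number of compound 2.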